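Notes on a distal aryl change in the series

The source may report more compounds than this note shows. Statements on the series, on what has been measured and on what is new or still open speak of the compounds shown alone.

Measured so far in an assay on isolated protein with Bile acid receptor (Homo sapiens) as the target; on this read-out higher numbers stand for an effect only at larger amounts of compound and lower numbers for an effect already at smaller amounts:
compound 1 `COC(=O)/C=C/c1cccc(N(Cc2ccc(-c3cccc(C)c3)cc2)C(=O)C(C)C)c1`: 163 nM
compound 2 `COC(=O)/C=C/c1cccc(N(Cc2ccc(-c3c(OC)cccc3OC)cc2)C(=O)C(C)C)c1`: 95 nM

Compound 2 holds the lowest of the two numbers in this assay; its nearest neighbour is compound 1, and the two lie within the scatter of each other, so no order between them can be read from the data.

Compound 3 `COC(=O)/C=C/c1cccc(N(Cc2ccc(-c3ccc(N(C)C)cc3)cc2)C(=O)C(C)C)c1` is not yet measured. It differs from compound 2 in one place: 4-(dimethylamino)phenyl in place of 2,6-dimethoxyphenyl on an aromatic carbon. The group that changes sits on an aromatic carbon, para to a large group.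

Among the compounds with values here, only one measured step bears on this position. It is a 1.7-fold lower number from compound 1 to compound 2 (0.23 log units; within the scatter), a change of the same distal aryl group that stayed within the scatter. The data therefore give no sign that substitution on this aryl moves the number beyond the scatter, in either direction. For compound 3 the step is expected to be a 1.3-fold higher number from compound 2 to compound 3 (0.10 log units; within the scatter), which amounts to no change beyond the scatter. Within the data shown here, on this basis compound 3 is estimated at 120 nM in this assay, with a range from 40 nM to 400 nM, the width reflecting that only a single comparable step is known.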

Compound 3, half-maximal effective concentration: 57 nM
Estimate against measurement, compound 3: 2.1-fold (0.32 log units) above, and the stated range covers the measured number.
By their numbers in this assay, from the lowest: compounds 3, 2 and 1 (each within the scatter of the next, the first and the last beyond it).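

In this assay, moving from the 2,6-dimethoxyphenyl group to the 4-(dimethylamino)phenyl group gives a 1.7-fold lower number from compound 2 to compound 3 (0.22 log units; within the scatter) and so shows no difference between these two groups. Moving from the 3-methylphenyl group to the same 4-(dimethylamino)phenyl group gives a 2.9-fold lower number from compound 1 to compound 3 (0.46 log units; beyond the scatter) and is the only step at this position so far to pass the scatter, so the choice of distal aryl can move the number, if only modestly, while compound 2 remains within the scatter of both neighbours. No supporting data bear on what lies behind this step.

From the compounds shown here alone, it remains open whether the step belongs to the dimethylamino group itself or to its place on the ring, which a plain phenyl, a 4-methoxyphenyl or a 3-(dimethylamino)phenyl group at the same carbon would help to separate. Going by these compounds, it is also open whether the same step would hold with the rest of the molecule changed, for example with a carboxylic acid in place of the methyl ester.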